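The source may hold more compounds than are shown below. What is called first, only, known or untested is meant among the compounds shown, and "the series" means these compounds.

The series shares one core, carried by compound 1 `COc1cc(-c2ccnc3cc(-c4ccc(C(C)=O)cc4)nn23)cc(OC)c1OC`, compound 2 `COc1cc(-c2ccnc3cc(-c4ccc(N(C)C)cc4)nn23)cc(OC)c1OC` and compound 3 `COc1cc(-c2ccnc3cc(-c4ccc5cnn(C)c5c4)nn23)cc(OC)c1OC`; the unmeasured compound 4 `COc1cc(-c2ccnc3cc(-c4cccc(C#N)c4)nn23)cc(OC)c1OC` belongs to the same set. In a functional assay on MCF7 cells (Homo sapiens) for inhibition, read by CCK-8 assay, with a stated time of 48 h (on this read-out lower numbers stand for stronger inhibition and higher numbers for weaker inhibition), compound 1 gives 5230 nM, compound 2 gives 44 nM and compound 3 gives 279 nM. Compound 3 thus stands second highest of the three numbers: nearest to it is compound 2, with a 6.3-fold higher number from compound 2 to compound 3 (0.80 log units; beyond the scatter), and furthest compound 1, with a 19-fold lower number from compound 1 to compound 3 (1.27 log units; beyond the scatter). The widest step in the set is a 120-fold lower number from compound 1 to compound 2 (2.08 log units; beyond the scatter).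

The step to compound 4 is 3-cyanophenyl in place of 1-methyl-1H-indazol-6-yl on an aromatic carbon. Going by the values given here, two measured steps bear on it. The step of a 19-fold lower number from compound 1 to compound 3 (1.27 log units; beyond the scatter) shows that exchanging a phenyl carrying a carbonyl substituent for the indazolyl group gave a large gain in this assay; the reverse direction, leaving the indazolyl group for a phenyl bearing a nitrile, is the closest analogy and points towards a higher number for compound 4. The step of a 6.3-fold higher number from compound 2 to compound 3 (0.80 log units; beyond the scatter) shows that another substituted phenyl also landed well away from compound 3, in the other direction. Among the compounds with values here, no measured pair holds a nitrile, so the size is uncertain. For compound 4 in this assay a higher number is expected, a 5.4-fold higher number from compound 3 to compound 4 (0.73 log units; beyond the scatter), estimated at 1500 nM with a range of 400 nM to 6000 nM.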

Compound 4, half-maximal inhibitory concentration: > 10000 nM
Compound 4: no number, only a limit (the forecaster's own chance of this, stated with the estimate: 5%); middle value at least 6.6-fold (0.82 log units) away from the limit.
By their numbers in this assay, from the lowest: compound 2; then compound 3; then compound 1. At a limit, above all of these: compound 4.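

Compound 4 gives no number in this assay, only a limit: the limit of > 10000 nM in this assay, at which 1 of the 4 values shown sits. On this aromatic carbon of the five-membered aromatic ring, 3-cyanophenyl shows an at least 35-fold higher number from compound 3 to compound 4 (1.55 log units; beyond the scatter) and an at least 220-fold higher number from compound 2 to compound 4 (2.35 log units; beyond the scatter), so this phenyl bearing a nitrile does not keep the level reached with 1-methyl-1H-indazol-6-yl or 4-(dimethylamino)phenyl. Against 4-acetylphenyl the step is an at least 1.9-fold higher number from compound 1 to compound 4 (0.28 log units; that floor lies within the scatter), a floor that lies within the scatter, so compound 1 and compound 4 cannot be put in order; two substituted phenyl groups now sit at the high end of the set, while compound 2 goes against any reading that a substituted phenyl at this position is poor in itself.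

As far as these compounds go, it remains open whether the nitrile itself or its place on the phenyl sets the result of compound 4, a question that 4-cyanophenyl would separate. Also open, from the compounds shown here alone, is whether other groups on the phenyl, such as a primary amine or a methoxy group, would stay close to compound 2.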